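The source may hold more compounds than are shown below. What is called first, only, known or untested is meant among the compounds shown, and "the series" means these compounds.

Values measured so far in a physicochemical assay for lipophilicity, at pH 7.4 (a lower number here means a more polar compound, a higher number a more lipophilic compound), are:
- Compound 1 `CNC(=O)c1cc(C(=O)N[C@H]2[C@@H]3COC[C@@H]32)cc2c1OC[C@H]2c1cccnc1` gives 1.4
- Compound 2 `CNC(=O)c1cc(C(=O)NC2CC2)cc2c1OC[C@H]2c1cccc2[nH]ccc12` gives 3.5
- Compound 3 `CNC(=O)c1cc(C(=O)N[C@H]2[C@@H]3C[C@H](O)C[C@@H]32)cc2c1OC[C@@]2(C)c1ccccc1` gives 3.7

Compound 3 (3.7) stands within the usual scatter of compound 2 (3.5). The gap between compound 3 and compound 1 (1.4) lies beyond the scatter, with compound 1 the lower.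

Compound 4 `CNC(=O)c1cc(C(=O)N[C@H]2[C@@H]3COC[C@@H]32)cc2c1OC[C@@]2(C)c1ccccc1` has not yet been measured. It departs from compound 3 in one place, on an amide-type nitrogen a group of 6 heavy atoms (5 carbon, 1 oxygen; one three-membered non-aromatic ring of carbon only, one five-membered non-aromatic ring with 1 hetero atom) in place of a group of 7 heavy atoms (6 carbon, 1 oxygen; one three-membered non-aromatic ring of carbon only, one five-membered non-aromatic ring of carbon only), on an amide-type nitrogen and nowhere else. Among the compounds with values here, no two measured compounds differ in one place only, so no measured step guides this change directly. In this assay no step beyond the scatter is expected, in either direction. The estimated change is small, a number 0.10 log units higher from compound 3 to compound 4 (within the scatter) and no more than that is expected. Compound 4 is expected at 3.8 (estimated range 3.4 to 4.3).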

Compound 4, distribution coefficient: 3.7
Beside the measured number, compound 4's estimate is 0.10 log units above it; the measured number falls inside the stated range.
By their numbers in this assay, from the lowest: compound 1; then compounds 2, 3 and 4 (each within the scatter of the next).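

In this assay, within the data shown here, exchanging the group of 7 heavy atoms for the group of 6 heavy atoms on the amide-type nitrogen gives no change at the digits printed from compound 3 to compound 4 (within the scatter) and provides the first single-place step at this position. On this core, the loss of the hydrogen-bond donor counted in the departing group and the change to a five-membered ring with 1 hetero atom therefore come with no step beyond the scatter. Nothing measured here accounts for this result.

As far as these compounds go, whether the same step would hold on another core remains open. So does what an amine or a carboxylic acid on this amide-type nitrogen would do to the read-out.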